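Nitrophenyl replacing hydroxymethoxyphenyl on the saturated ring carbon

This account rests on a few compounds, and the source may have more. Where it says the series, first, only, none or still open, it means among the compounds named here.

Compound 1 `COc1cccc(C2C=C(c3cc(OC)c(OC)c(OC)c3)NC(=S)N2)c1`: > 100000 nM (a limit)
Compound 2 `COc1ccc(C2C=C(c3cc(OC)c(OC)c(OC)c3)NC(=S)N2)cc1O`: 500 nM
Compound 3 `COc1ccc(C2C=C(c3cc(OC)c(OC)c(OC)c3)NC(=S)N2)cc1[N+](=O)[O-]`: > 100000 nM (a limit)

Going by the values given here, in a functional assay on L1210 cells (Mus musculus) for cytotoxicity, read by MTT assay, with a stated time of 72 h (a lower number here means a stronger inhibitor, a higher number a weaker inhibitor), compound 2 gives 500 nM, the only actual number among the three measured compounds. For compound 1 the value > 100000 nM is a limit of the assay. For compound 3 the value > 100000 nM is likewise a limit. Compound 4 `COc1cc(C2=CC(c3ccc([N+](=O)[O-])cc3)NC(=S)N2)cc(OC)c1OC` has not been measured; it carries 4-nitrophenyl in place of 3-hydroxy-4-methoxyphenyl on a saturated ring carbon. Among the compounds with values here, two measured steps bear on this change: an at least 200-fold lower number from compound 1 to compound 2 (2.30 log units; beyond the scatter), and an at least 200-fold higher number from compound 2 to compound 3 (2.30 log units; beyond the scatter). Both steps run between compound 2 and (the limit of > 100000 nM in this assay, at which 2 of the 3 values shown sit). Compound 4 lacks the hydroxy of compound 2 and bears a nitro, and in line with an at least 200-fold higher number from compound 2 to compound 3 (2.30 log units; beyond the scatter) a large rise is expected, a 160-fold higher number from compound 2 to compound 4 (2.20 log units; beyond the scatter). Compound 4 is estimated at 80000 nM, between 5000 nM and 300000 nM.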

Compound 4, half-maximal inhibitory concentration: > 100000 nM
Compound 4 ended at the assay's limit; the forecaster's own chance of this, stated with the estimate: 70%; at least 1.2-fold (0.09 log units) between middle value and limit.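

In this assay compound 4 gives > 100000 nM as a limit of the assay, not a number. Placing 4-nitrophenyl instead of 3-hydroxy-4-methoxyphenyl on this saturated ring carbon gives an at least 200-fold higher number from compound 2 to compound 4 (2.30 log units; beyond the scatter) and shows that the loss also occurs with a different phenyl substitution, leaving compound 2 as the only compound with a readable value: the limit of > 100000 nM in this assay, at which 3 of the 4 values shown sit. The step from compound 1 to compound 4 cannot be read.

From the compounds shown here alone, how far compound 1, compound 3 and compound 4 lie past the limit stays open. So does whether an amine or a carboxylic acid in place of the hydroxy would give a readable value.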